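The source may hold more compounds than are shown below. What is called first, only, known or untested is meant among the compounds shown, and "the series" means these compounds.

Measured compounds:
- compound 1 `CCCCC[C@H](CN(O)C=O)C(=O)NCNC(=O)c1ccc(-c2cccc(C(=O)O)c2)o1`: 8 nM
- compound 2 `CCCCC[C@@H](C(=O)NCNC(=O)c1cc2cccc(OC)c2o1)[C@@H](CC)N(O)C=O`: 126 nM
- compound 3 `COc1cccc2cc(C(=O)NCNC(=O)CCN(O)C=O)oc12`: 6300 nM

Of the compounds shown here, three have so far been tested in an assay on CHO cells for inhibition of bone morphogenetic protein 1 (Homo sapiens), with stated times of 10 min and 60 min; a lower number here means a stronger inhibitor, a higher number a weaker inhibitor. Compound 1 stands lowest of the three: compound 2 gives a number that is higher by a margin beyond the scatter, and compound 3 gives a number higher still, so compound 1 is the most potent inhibitor of the set in this assay. Among the measured compounds shown here, compounds 2 and 3 differ from compound 1 in more than one place, so no single step between measured compounds is available.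

The next compound, compound 4 `CCCCC[C@H](CN(O)C=O)C(=O)NCNC(=O)c1ccc(-c2cccc(OCC)c2)o1`, is derived from compound 1 by one change: ethoxy in place of carboxy on an aromatic carbon. For the measured compounds named here, nothing among the measured compounds isolates this exchange. The account therefore rests on an expectation only: a moderate loss of potency is expected in this assay, with the estimated step being a 3.8-fold higher number from compound 1 to compound 4 (0.57 log units; beyond the scatter). On that basis compound 4 is expected to give about 30 nM, within a range from 8 nM to 120 nM.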

Compound 4, half-maximal inhibitory concentration: 1 nM
Estimate against measurement, compound 4: 30-fold (1.48 log units) above; measured number below the stated range.
By their numbers in this assay, from the lowest: compound 4; then compound 1; then compound 2; then compound 3.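

In this assay, among the compounds shown here, replacing the 3-carboxyphenyl with the 3-ethoxyphenyl gives an 8.0-fold lower number from compound 1 to compound 4 (0.90 log units; beyond the scatter), the first step in this set that can be read at a single position. It shows that the carboxy group on this six-membered aromatic ring is not required for strong inhibition: with ethoxy in its place, and the hydrogen-bond donor of the carboxy gone, the number falls instead of rising. No measurement at hand bears on why this step occurs.

Whether this gain is specific to ethoxy stays open, since the compounds shown do not tell how a hydroxy, a methoxy or a longer alkoxy chain would read at this place. They also leave open how an amine or a carboxylic acid on a longer chain would compare there, and whether a substituent is needed on this ring at all.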